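The source may report more compounds than this note shows. Statements on the series, on what has been measured and on what is new or still open speak of the compounds shown alone.

Measured compounds:
compound 1 `O=C(Nc1cccc(-n2cc(-c3ccncc3)c(-c3cc(O)cc(Cl)c3)n2)c1)Nc1ccc(Cl)c(Cl)c1`, -52%
compound 2 `COc1cc(Cl)cc(-c2nn(-c3cccc(NC(=O)Nc4ccc(Cl)c(C(F)(F)F)c4)c3)cc2-c2ccncc2)c1`, -88%
compound 3 `COc1cc(Cl)cc(-c2nn(-c3cccc(NC(=O)Nc4ccc(Cl)c(Cl)c4)c3)cc2-c2ccncc2)c1`, -7%

These values come from a functional assay on SK-MEL-28 cells (Homo sapiens) for inhibition, read by sulforhodamine B assay, with a stated time of 48 h, tested at 100 uM; a lower number here means a stronger effect, a higher number a weaker effect of the compound at the concentration tested. Compound 3 stands highest of the three, so it shows the weakest effect: compound 1 sits lower and compound 2 lowest. Compound 4 `COc1cc(Cl)cc(-c2nn(-c3cccc(NC(=O)c4cccc(C(F)(F)F)c4)c3)cc2-c2ccncc2)c1` differs from compound 3 in one place: 3-(trifluoromethyl)phenyl in place of (3,4-dichlorophenyl)amino on a carbonyl carbon. Among the measured compounds shown here, no measured step removes an amino link in this way, so the pair that bears on it only loosely is the exchange of a ring substituent, a number 81 percentage points higher from compound 2 to compound 3 (beyond the scatter), a large step in which the trifluoromethyl-bearing compound gave the lower number. The other step, a number 45 percentage points higher from compound 1 to compound 3 (beyond the scatter), touches a different part and carries little weight here. As far as these compounds go, the change is untested, so a lowering is expected but with wide uncertainty, a number 33 percentage points lower from compound 3 to compound 4 (beyond the scatter). Compound 4 is therefore estimated at -40%, between -90% and 10%.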

Compound 4, a percentage reported as activity, at one concentration (the size of the read-out at that concentration, not a potency): 75%
Compound 4: the middle estimate sits 115 percentage points below what was measured; the measured number lies above the stated range.
By their numbers in this assay, from the lowest: compound 2; then compound 1; then compound 3; then compound 4.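

In this assay the exchange on the carbonyl carbon gives a number 82 percentage points higher from compound 3 to compound 4 (beyond the scatter) and also a number 163 percentage points higher from compound 2 to compound 4 (beyond the scatter) when the group leaving is (4-chloro-3-(trifluoromethyl)phenyl)amino. The earlier steps shown here all kept the amino link, whereas these two remove it together with its hydrogen-bond donor, and both move toward a weaker effect. Nothing measured here explains this shift.

The ring substituents change along with the link, so the two changes cannot be told apart. A methylene link in place of the amino nitrogen would help separate them.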